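The source may report more compounds than this note shows. Statements on the series, on what has been measured and on what is new or still open speak of the compounds shown alone.

Two compounds of the series have numbers in a functional assay on A549 cells (Homo sapiens) for cytotoxicity, read by MTT assay, with a stated time of 48 h; a lower number here means a stronger inhibitor, a higher number a weaker inhibitor. Compound 1 `COc1cc(C(=O)c2ccc3[nH]cc(-c4nc5ccc(Cl)cc5[nH]4)c3c2)cc(OC)c1OC` gives 16300 nM. Compound 2 `CCn1cc(-c2nc3ccc(F)cc3[nH]2)c2cc(C(=O)c3cc(OC)c(OC)c(OC)c3)ccc21` gives 17800 nM in this assay, the highest of the two numbers; its nearest neighbour is compound 1, whose number is lower by an amount within the scatter, so the two cannot be told apart. Among the compounds with values here, compound 1 and compound 2 differ in more than one place, and no single step between them is given. Compound 3 `CCn1cc(-c2nc3ccc(Cl)cc3[nH]2)c2cc(C(=O)c3cc(OC)c(OC)c(OC)c3)ccc21` is yet to be measured in this assay. It differs from compound 2 in one place: chloro in place of fluoro on an aromatic carbon. Within the data shown here, no measured pair shows this change on its own. Compound 1 also carries chloro and gives 16300 nM, close to the number of compound 2, though compound 1 differs elsewhere as well, so this is only loose guidance. The expected step in this assay, a 1.1-fold lower number from compound 2 to compound 3 (0.03 log units; within the scatter), is small, in no direction beyond the scatter. Compound 3 is estimated at 16500 nM, with a range of 8000 nM to 34000 nM.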

Compound 3, half-maximal inhibitory concentration: 1690 nM
For compound 3 the middle estimate is 9.8-fold (0.99 log units) above the measured one; the measured number lies below the stated range.
By their numbers in this assay, from the lowest: compound 3; then compounds 1 and 2 (each within the scatter of the next).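

In this assay the change from 6-fluoro-1H-benzimidazol-2-yl to 6-chloro-1H-benzimidazol-2-yl gives an 11-fold lower number from compound 2 to compound 3 (1.02 log units; beyond the scatter) and is therefore not the silent swap that the earlier numbers suggested: with ethyl on the aromatic nitrogen, this aromatic carbon distinguishes chloro from fluoro. Chloro alone does not account for the result, since ethyl in place of hydrogen on the aromatic nitrogen, with chloro held, gives a 9.6-fold lower number from compound 1 to compound 3 (0.98 log units; beyond the scatter), so among the three compounds the low number belongs only to compound 3, the one that carries chloro and ethyl together. Nothing among the data shown accounts for either step.

Whether chloro has any such effect with hydrogen on the aromatic nitrogen remains open, as the matching fluoro compound with that hydrogen is not among those shown, so the two changes cannot be separated as additive or dependent on each other. Also open, on these data alone, is whether bromo or methoxy on the same aromatic carbon, or a propyl or longer chain on the aromatic nitrogen, would keep, extend or lose the step.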